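The source may hold more compounds than are shown below. What is called first, only, known or untested is meant among the compounds shown, and "the series" means these compounds.

Compounds measured in a functional assay for antagonist activity at Alpha-1A adrenergic receptor (Oryctolagus cuniculus); on this read-out higher numbers stand for weaker binding and lower numbers for tighter binding:
compound 1, `COc1ccccc1N1CCN(CCCNc2ncccc2C(=O)N(C)C)CC1`: 1.59 nM
compound 2, `CN(C)C(=O)c1cccnc1NCCCN1CCN(c2ccccc2)CC1`: 6.31 nM
compound 3, `CN(C)C(=O)c1cccnc1NCCCN1CCN(c2ccccc2OCC(F)(F)F)CC1`: 0.1 nM

Compound 3 gives the lowest number of the three, and both its neighbours stand beyond the scatter: the step is a 16-fold lower number from compound 1 to compound 3 (1.20 log units; beyond the scatter) and a 63-fold lower number from compound 2 to compound 3 (1.80 log units; beyond the scatter). Compound 4, `CN(C)C(=O)c1cccnc1NCCCN1CCN(c2ccccc2-c2ccccc2)CC1`, takes the change (phenyl in place of 2,2,2-trifluoroethoxy on an aromatic carbon). Within the data shown here, two measured steps touch the same place: the trifluoroethoxy group itself produced the large step of a 63-fold lower number from compound 2 to compound 3 (1.80 log units; beyond the scatter), while taking away a methoxy there produced the modest step of a 4.0-fold higher number from compound 1 to compound 2 (0.60 log units; beyond the scatter). Among the measured compounds shown here, no measured step tells what a phenyl does there, so the number for compound 4 is expected to rise from that of compound 3, with the size of that rise uncertain, estimated as a 30-fold higher number from compound 3 to compound 4 (1.48 log units; beyond the scatter). Compound 4 is therefore expected to give about 3 nM in this assay, within a range from 0.6 nM to 15 nM.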

Compound 4, dissociation constant: 1.26 nM
Estimate against measurement, compound 4: 2.4-fold (0.38 log units) above; the range from low to high includes it.
By their numbers in this assay, from the lowest: compound 3; then compounds 4 and 1 (each within the scatter of the next); then compound 2.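

In this assay, phenyl, which has no hydrogen-bond acceptor, still beats bare hydrogen at this aromatic carbon (a 5.0-fold lower number from compound 2 to compound 4 (0.70 log units; beyond the scatter)), yet it loses much of the gain seen with 2,2,2-trifluoroethoxy (a 13-fold higher number from compound 3 to compound 4 (1.10 log units; beyond the scatter)). Phenyl and methoxy cannot be told apart here (a 1.3-fold lower number from compound 1 to compound 4 (0.10 log units; within the scatter)), so a ring and a small oxygen-linked group can serve about equally at this place. Nothing available explains these differences.

Going by these compounds, whether plain ethoxy, lacking the fluorines, would match 2,2,2-trifluoroethoxy remains open. So does the outcome with an amine or a nitrile on this carbon.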